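Amide nitrogen substituents on a shared core in paw edema

The source may hold more compounds than are shown below. What is called first, only, known or untested is meant among the compounds shown, and "the series" means these compounds.

The measured compounds are compound 1 `O=C(Nc1ccccc1)c1c(O)c2cccnc2n(-c2ccccc2)c1=O` with 4.6% and compound 2 `O=C(Nc1nccs1)c1c(O)c2cccnc2n(-c2ccccc2)c1=O` with 4.6%.

In a functional assay on the whole organism for inhibition, with Rattus norvegicus as the target, read by paw edema, at a dose of 100 mg/kg by the oral route (on this read-out higher numbers stand for more inhibition at the one dose given (going by the name of the read-out) and lower numbers for less inhibition), compound 1 gives 4.6%. Compound 2 stands level with it, giving 4.6%; the step of no change at the digits printed from compound 1 to compound 2 (within the scatter) lies within the scatter. Compound 3 `O=C(NCc1cccnc1)c1c(O)c2cccnc2n(-c2ccccc2)c1=O` has not been measured. Its difference from compound 2 is (pyridin-3-yl)methyl in place of 1,3-thiazol-2-yl on an amide-type nitrogen. Among the measured compounds shown here, only one measured step is known, the exchange of phenyl for 1,3-thiazol-2-yl on the amide-type nitrogen, and it left the read-out unchanged. For the measured compounds named here, the entering (pyridin-3-yl)methyl has no direct precedent among the measured compounds, so no step beyond the scatter can be foreseen; the expected step is a number 1.4 percentage points higher from compound 2 to compound 3 (within the scatter). Compound 3 is therefore expected to give about 6%, within a range from -5% to 20%.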

Compound 3, a percentage reported as inhibition, in the whole organism at one dose (the size of the read-out at that dose, not a potency): 25.5%
Compound 3: the middle estimate sits 19.5 percentage points below what was measured; the measured number lies above the stated range.
By their numbers in this assay, from the lowest: compounds 1 and 2 (each within the scatter of the next); then compound 3.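

In this assay, the amide-type nitrogen turns out to be a place where a change can move the read-out: (pyridin-3-yl)methyl in place of 1,3-thiazol-2-yl gives a number 20.9 percentage points higher from compound 2 to compound 3 (beyond the scatter), and the same group in place of phenyl gives a number 20.9 percentage points higher from compound 1 to compound 3 (beyond the scatter). The entering group differs from both leaving groups in its ring and in the methyl that links the ring to the nitrogen, so these compounds cannot separate the share of each part. Nothing at hand explains the step.

On these data alone, it remains open whether benzyl, which keeps the methyl link on a plain phenyl ring, or pyridin-3-yl, which has the ring without the link, would reach the level of compound 3. Also open, as far as these compounds go, is how a longer chain, such as 2-(pyridin-3-yl)ethyl, would read at this nitrogen.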